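Urea aryl change on a thienopyrimidine cytotoxicity series

This account rests on a few compounds, and the source may have more. Where it says the series, first, only, none or still open, it means among the compounds named here.

Measured so far:
- compound 1, `CN(C)CCCNc1nc(-c2ccc(NC(=O)Nc3ccccc3F)cc2)nc2ccsc12`: 730 nM
- compound 2, `CCN(CC)CCNc1nc(-c2ccc(NC(=O)Nc3ccccc3F)cc2)nc2ccsc12`: 1040 nM

In a functional assay on MKN-45 cells (Homo sapiens) for cytotoxicity, read by MTT assay, with a stated time of 72 h (on this read-out higher numbers stand for weaker inhibition and lower numbers for stronger inhibition), compound 1 gives 730 nM and compound 2 gives 1040 nM. Among the compounds with values here, the only step measured so far, a 1.4-fold higher number from compound 1 to compound 2 (0.15 log units; within the scatter), changes the amine on the saturated chain and stays inside the scatter, so compound 2 stands alongside compound 1 with no separation that can be read as real.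

Compound 3, `CCN(CC)CCNc1nc(-c2ccc(NC(=O)Nc3ccc(Cl)cc3Cl)cc2)nc2ccsc12`, differs from compound 2 at the other end of the molecule: 2,4-dichlorophenyl in place of 2-fluorophenyl on an amide-type nitrogen. The shared core and the chain amine are untouched. Within the data shown here, no measured step touches the aryl on the urea; the single step in hand, a 1.4-fold higher number from compound 1 to compound 2 (0.15 log units; within the scatter), concerns a different part of the structure and therefore says nothing about this change. With nothing in the series to anchor it, no step beyond the scatter is expected in this assay, and the expected step of a 1.2-fold lower number from compound 2 to compound 3 (0.06 log units; within the scatter) is placed near zero with a wide range. Compound 3 is estimated at 900 nM, between 300 nM and 2800 nM.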

Compound 3, half-maximal inhibitory concentration: 1520 nM
For compound 3 the middle estimate is 1.7-fold (0.23 log units) below the measured one, and the stated range covers the measured number.
By their numbers in this assay, from the lowest: compounds 1, 2 and 3 (each within the scatter of the next, the first and the last beyond it).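

In this assay, within the data shown here, this is the first measured change to the aryl on the urea: 2,4-dichlorophenyl in place of 2-fluorophenyl on an amide-type nitrogen gives a 1.5-fold higher number from compound 2 to compound 3 (0.16 log units; within the scatter), with the shared core and the diethylamino chain held constant. The earlier step concerned only the amine on the saturated chain, whereas this pair shows that the read-out does not separate these two halogen-bearing phenyl groups, a finding that rests on this single pair. No supporting data are available to explain the result.

On these data alone, it remains open whether the same aryl exchange would also stay within the scatter on the chain of compound 1, as the present pair tests it only with the diethylamino chain. As far as these compounds go, it is also open whether a urea aryl of a different kind, such as unsubstituted phenyl, a pyridine ring, or a phenyl carrying methoxy or trifluoromethyl, would produce a step beyond the scatter in this assay.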